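This account rests on a few compounds, and the source may have more. Where it says the series, first, only, none or still open, it means among the compounds named here.

Compound 2 `CN1CCC(C(=O)N2Cc3c(NC(=O)c4ccco4)n[nH]c3C2(C)C)CC1` stands at the ceiling of a physicochemical assay for solubility, at pH 7; on this read-out higher numbers stand for higher solubility and lower numbers for lower solubility: in this assay compound 2 gives > 225000 nM, which is a limit of the measurement and not a number. Compound 1 `CN1CCC(C(=O)N2Cc3c(NC(=O)Nc4cccc(F)c4)n[nH]c3C2(C)C)CC1` likewise gives > 225000 nM in this assay, again a limit. Compound 3 `CC(C)(C)C(=O)N1Cc2c(NC(=O)c3cccnc3)n[nH]c2C1(C)C` gives 207000 nM in this assay. Going by the values given here, the only measured step between single-point changes, a step that the two limits leave unreadable from compound 1 to compound 2, cannot be sized because of the limit of > 225000 nM in this assay, at which 2 of the 3 values shown sit.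

Compound 4 `CN1CCC(C(=O)N2Cc3c(NC(=O)c4cccc(F)c4)n[nH]c3C2(C)C)CC1` arises from compound 2 by the change (3-fluorophenyl in place of furan-2-yl on a carbonyl carbon). No readable measured step bears on this change, so the expectation rests on all three values sitting close together. Compound 4 is expected to give 180000 nM in this assay, within 70000 nM to 225000 nM. The expected step from compound 2 is an at least 1.2-fold lower number from compound 2 to compound 4 (0.09 log units; that floor lies within the scatter), none beyond the scatter.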

Compound 4, solubility: > 225000 nM
Compound 4 ended at the assay's limit; the forecaster's own chance of this, stated with the estimate: 55%; middle value at least 1.2-fold (0.09 log units) from the limit.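

The steps among compound 1, compound 2 and compound 4 cannot be read in this assay because all three values are limits: the limit of > 225000 nM in this assay, at which 3 of the 4 values shown sit.

The compounds shown leave open how far compound 1, compound 2 and compound 4 lie apart in this assay.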